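The source may hold more compounds than are shown below. What is called first, only, known or untested is meant among the compounds shown, and "the series" means these compounds.

Measured compounds in a functional assay on ME-180 cells (Homo sapiens) for cytotoxicity, read by MTT assay, with a stated time of 72 h; on this read-out higher numbers stand for weaker inhibition and lower numbers for stronger inhibition:
Compound 1 `COc1ccc(/C=C/C(=O)Nc2cc(C(=O)c3cc(OC)c(OC)c(OC)c3)cc(OC)c2OC)cc1`: 12500 nM
Compound 2 `C#CCOc1cccc(/C=C/C(=O)Nc2cc(C(=O)c3cc(OC)c(OC)c(OC)c3)cc(OC)c2OC)c1`: 8400 nM
Compound 3 `COc1cc(C(=O)c2cc(OC)c(OC)c(OC)c2)cc(NC(=O)/C=C/c2ccc(F)cc2)c1OC`: 1000 nM

Compound 3 stands lowest of the three, with a 13-fold lower number from compound 1 to compound 3 (1.10 log units; beyond the scatter) and an 8.4-fold lower number from compound 2 to compound 3 (0.92 log units; beyond the scatter), both beyond the scatter, while a 1.5-fold lower number from compound 1 to compound 2 (0.17 log units; within the scatter) stays within it.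

Compound 4 `COc1cc(C(=O)c2cc(OC)c(OC)c(OC)c2)cc(NC(=O)/C=C/c2ccc(C(F)(F)F)cc2)c1OC` differs from compound 3 by trifluoromethyl in place of fluoro on an aromatic carbon. Within the data shown here, no measured step exchanges one such group for another on this ring; the two steps that bear on the position, both with fluoro entering, were large and modest and both ran toward lower numbers. They say nothing about trifluoromethyl against fluoro, so for compound 4 a step within the scatter is expected, a 1.5-fold higher number from compound 3 to compound 4 (0.18 log units; within the scatter), with the estimate for compound 4 in this assay at 1500 nM, ranging from 400 nM to 6000 nM.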

Compound 4, half-maximal inhibitory concentration: 3600 nM
For compound 4 the middle estimate is 2.4-fold (0.38 log units) below the measured one, within the range that was stated.
By their numbers in this assay, from the lowest: compound 3; then compound 4; then compounds 2 and 1 (each within the scatter of the next).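

In this assay, among these compounds, this position now shows that fluoro is not the only group to give a lower number than methoxy, and that the choice of replacement matters, with a 3.6-fold higher number from compound 3 to compound 4 (0.56 log units; beyond the scatter) in favour of fluoro. Trifluoromethyl keeps a gain over methoxy, with a 3.5-fold lower number from compound 1 to compound 4 (0.54 log units; beyond the scatter) and over 3-(propargyloxy)phenyl as the whole aryl group, with a 2.3-fold lower number from compound 2 to compound 4 (0.37 log units; beyond the scatter) on that exchange. Nothing measured here explains these differences.

Where chloro, a nitrile or an amine would fall on this ring relative to fluoro and trifluoromethyl remains open. Going by these compounds, whether fluoro elsewhere on the ring would hold the number of compound 3 is also open.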